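The source may report more compounds than this note shows. Statements on the series, on what has been measured and on what is new or still open speak of the compounds shown alone.

In a functional assay on Huh-7 cells (Homo sapiens) for inhibition, read by CCK-8 assay, with a stated time of 72 h (on this read-out lower numbers stand for stronger inhibition and higher numbers for weaker inhibition), compound 1 `O=C(/C=C/c1cccnc1)NCCCCCCc1ccc(S(=O)(=O)Nc2ccccc2)cc1` gives 112 nM and compound 2 `O=C(/C=C/c1cccnc1)NCCCCCCCc1cccc(S(=O)(=O)Nc2ccccc2)c1` gives 138 nM within the scatter of each other. Compound 3 `Cc1cccc(NS(=O)(=O)c2cccc(CCCCCCNC(=O)/C=C/c3cccnc3)c2)c1` stands lowest of the three at 13.2 nM with both gaps beyond the scatter. Compound 4 `O=C(/C=C/c1cccnc1)NCCCCCCc1cccc(S(=O)(=O)Nc2ccc(Cl)cc2)c1` is still unmeasured and departs from compound 3 by 4-chlorophenyl in place of 3-methylphenyl on a sulfonamide nitrogen with 4-chlorophenyl in place of 3-methylphenyl on a sulfonamide nitrogen. Within the data shown here, no measured pair shows this change alone, so the expectation remains loose. In this assay the estimated 2.3-fold higher number from compound 3 to compound 4 (0.36 log units; beyond the scatter) is a moderate rise in the number, only just beyond the scatter. Compound 4 is expected at 30 nM with an estimated range of 8 nM to 120 nM on this read-out.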

Compound 4, half-maximal inhibitory concentration: 24.1 nM
For compound 4 the middle estimate is 1.2-fold (0.10 log units) above the measured one; the measured number falls inside the stated range.
By their numbers in this assay, from the lowest: compounds 3 and 4 (each within the scatter of the next); then compounds 1 and 2 (each within the scatter of the next).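

Within this assay the sulfonamide nitrogen takes 4-chlorophenyl in place of 3-methylphenyl with a 1.8-fold higher number from compound 3 to compound 4 (0.26 log units; within the scatter) and the two numbers cannot be told apart. The low number of compound 3 is therefore not tied to 3-methylphenyl at this place, as a second aryl group serves equally well. No measurement shown here offers an explanation for this.

Because the step changes both the substituent and its place on the ring, the two remain unseparated, which 3-chlorophenyl or 4-methylphenyl on the same nitrogen could resolve. On these data alone, how a carboxylic acid or an amine on that ring would read stays open.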